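The source may report more compounds than this note shows. Statements on the series, on what has been measured and on what is new or still open speak of the compounds shown alone.

Measured compounds:
Compound 1 `CCOC(=O)CN(C(=O)/C(C)=C/c1ccc(C(=O)Oc2ccc(C(=N)N)cc2)cc1)C1CCCCC1` in an in vitro ADME assay on a cell-free system (plasma) for pharmacokinetics (on this read-out lower numbers stand for a shorter-lived compound and higher numbers for a longer-lived compound), gives < 0.0834 h, which is a limit of the assay and not a number.
Compound 2 `CCOC(=O)C(C(=O)OCC)N(CCCC(=O)O)C(=O)/C(C)=C/c1ccc(C(=O)Oc2ccc(C(=N)N)cc2)cc1` in this assay gives 0.483 h.
Compound 3 `CCOC(=O)CCCN(C(=O)/C(C)=C/c1ccc(C(=O)Oc2ccc(C(=N)N)cc2)cc1)C(C(=O)O)C(=O)OCC` in this assay gives 0.233 h.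

Compound 1 sits at the limit of < 0.0834 h in this assay, at which 1 of the 3 values shown sits, so only an upper bound is known for it, and its place on the scale is the shortest-lived end of what this assay can resolve. Compound 2 and compound 3, which share the core of compound 1 and each carry a carboxy group, returned measurable numbers; with no step listed between either of them and compound 1, their values are only noted as they stand.

The unmeasured compound 4 `C/C(=C\c1ccc(C(=O)Oc2ccc(C(=N)N)cc2)cc1)C(=O)N(CC(=O)O)C1CCCCC1` is derived from compound 1 by a single change: hydrogen in place of ethyl on an oxygen next to a carbonyl group. Because compound 1 gives < 0.0834 h, any measurable number for compound 4 would mean a step upward. Compound 4 is expected to show a sizeable upward step, an at least 17-fold higher number from compound 1 to compound 4 (1.25 log units; beyond the scatter), clearly beyond the scatter. Compound 4 is therefore estimated in this assay at 1.5 h, with a likely range from 0.3 h to 6 h.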

Compound 4, half-life: > 1 h
Compound 4: no number, only a limit; the forecaster's own chance of this, stated with the estimate: 10%; the middle value does not contradict the limit.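

In this assay, hydrogen in place of ethyl on an oxygen next to a carbonyl group, which turns (ethoxycarbonyl)methyl into carboxymethyl, gives an at least 11-fold higher number from compound 1 to compound 4 (1.07 log units; beyond the scatter), and this is the only single-place change that can be read among the compounds shown. Compound 1 stands at a limit of the assay, not at a number: the limit of < 0.0834 h in this assay, at which 1 of the 4 values shown sits. Compound 4 also stands at a limit and not at a number: the limit of > 1 h in this assay, at which 1 of the 4 values shown sits.

As far as these compounds go, how far compound 4 lies past its limit remains open, so the true size of the step is not fixed. Also open, from the compounds shown here alone, is whether a methyl ester or a primary amide in place of the ethoxycarbonyl group would shift the half-life in the same direction, or by a similar amount.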